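Hydrazone Analogues on Fibroblasts: Expected Behaviour of a Fluorinated Member

The source may hold more compounds than are shown below. What is called first, only, known or untested is meant among the compounds shown, and "the series" means these compounds.

Compound 1 `O=C(NN=C1CC(c2ccccc2)NC(c2ccccc2)C1)c1ccc(Cl)cc1` carries a chloro group, compound 2 `COc1ccc(C(=O)NN=C2CC(c3ccccc3)NC(c3ccccc3)C2)cc1` a methoxy group, and compound 3 `O=C(NN=C1CC(c2ccccc2)NC(c2ccccc2)C1)c1ccc([N+](=O)[O-])cc1` a nitro group on the same shared core. In a toxicity assay on BJ cells (Homo sapiens) for cytotoxicity, read by MTT assay, with a stated time of 24 h (on this read-out higher numbers stand for weaker inhibition and lower numbers for stronger inhibition), compound 1 gives only a limit, > 400000 nM. Compound 2 likewise shows only a limit, > 400000 nM. Compound 3 also stands at a limit, > 400000 nM. The steps a step that the two limits leave unreadable from compound 1 to compound 2, a step that the two limits leave unreadable from compound 1 to compound 3 and a step that the two limits leave unreadable from compound 2 to compound 3 are thus unreadable, all three values resting at the limit of > 400000 nM in this assay, at which 3 of the 3 values shown sit. Compound 4 `O=C(NN=C1CC(c2ccccc2)NC(c2ccccc2)C1)c1ccc(F)cc1C(F)(F)F` differs from compound 3 by 4-fluoro-2-(trifluoromethyl)phenyl in place of 4-nitrophenyl on a carbonyl carbon. With every measured step unreadable, no direction can be read, and the step that the limit leaves unreadable from compound 3 to compound 4 is expected to stay within the scatter. Compound 4 is therefore estimated at 500000 nM, between 200000 nM and 2000000 nM, most likely reported once more only as a limit.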

Compound 4, half-maximal inhibitory concentration: > 400000 nM
Compound 4 was reported as a limit; the forecaster's own chance of this, stated with the estimate: 80%; the middle value does not contradict the limit.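

Among these compounds, no step from compound 1, compound 2 or compound 3 to compound 4 can be read in this assay, since each value is only a limit: the limit of > 400000 nM in this assay, at which 4 of the 4 values shown sit. The compounds shown leave open whether exchanging the group on the carbonyl carbon changes the read-out at all.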